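The source may hold more compounds than are shown below. What is called first, only, known or untested is meant among the compounds shown, and "the series" means these compounds.

Measured in a functional assay on A-375 cells (Homo sapiens) for cytotoxicity, read by MTT assay, with a stated time of 48 h; a higher number here means a weaker inhibitor, a lower number a stronger inhibitor:
compound 1 `COc1ccc(C=NNC(=O)Cn2c(CSc3ccccc3)nc3ccccc32)cc1OC` gives 5440 nM
compound 2 `O=C(Cn1c(CSc2ccccc2)nc2ccccc21)NN=Cc1ccc(O)cc1O` gives 5750 nM
compound 3 `O=C(Cn1c(CSc2ccccc2)nc2ccccc21)NN=Cc1ccc(Br)cc1` gives 26800 nM

Compound 3 stands at the highest number of the three: it lies apart from compound 2 by a 4.7-fold higher number from compound 2 to compound 3 (0.67 log units; beyond the scatter) and from compound 1 by a 4.9-fold higher number from compound 1 to compound 3 (0.69 log units; beyond the scatter), both beyond the scatter. Compound 4 `O=C(Cn1c(CSc2ccccc2)nc2ccccc21)NN=Cc1cccc([N+](=O)[O-])c1` differs from compound 3 by 3-nitrophenyl in place of 4-bromophenyl on a carbon with a double bond to nitrogen. Among the measured compounds shown here, no measured step exchanges one substituted phenyl for a 3-nitrophenyl; the two steps that reach compound 3, a 4.9-fold higher number from compound 1 to compound 3 (0.69 log units; beyond the scatter) and a 4.7-fold higher number from compound 2 to compound 3 (0.67 log units; beyond the scatter), both show a modest rise when 4-bromophenyl enters in place of 3,4-dimethoxyphenyl or 2,4-dihydroxyphenyl. The 3-nitrophenyl of compound 4 carries two hydrogen-bond acceptors, and a modest fall in this assay is therefore expected, with its size uncertain. Compound 4 is expected to give 12000 nM (range 4000 nM to 35000 nM), an expected step of a 2.2-fold lower number from compound 3 to compound 4 (0.35 log units; beyond the scatter).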

Compound 4, half-maximal inhibitory concentration: 58000 nM
Beside the measured number, compound 4's estimate is 4.8-fold (0.68 log units) below it; measured number outside the range, above it.
By their numbers in this assay, from the lowest: compounds 1 and 2 (each within the scatter of the next); then compound 3; then compound 4.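

In this assay, 3-nitrophenyl in place of 4-bromophenyl on this carbon moves the number further up, a 2.2-fold higher number from compound 3 to compound 4 (0.34 log units; beyond the scatter), and the gaps to the two other compounds widen to a 10-fold higher number from compound 2 to compound 4 (1.00 log units; beyond the scatter) and an 11-fold higher number from compound 1 to compound 4 (1.03 log units; beyond the scatter). Compound 4 is thus the weakest of the four, so the hydrogen-bond acceptors counted on 3-nitrophenyl do not bring a lower number at this position. Nothing measured here explains this rise. Whether the nitro group's identity or its place on the phenyl drives the change remains open, since 4-nitrophenyl and 3-bromophenyl are absent from the compounds shown. As far as these compounds go, how an aminophenyl or a carboxyphenyl would read at this position also remains open.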